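The source may hold more compounds than are shown below. What is called first, only, known or untested is meant among the compounds shown, and "the series" means these compounds.

Values measured in a physicochemical assay for solubility, measured as kinetic solubility (on this read-out higher numbers stand for higher solubility and lower numbers for lower solubility), for three compounds:
- compound 1 `CNc1nccc(N2CC[C@H](NC(=O)Nc3ccc(CN4CCC4)c(C(F)(F)F)c3)C2)n1` gives 84900 nM
- compound 2 `CNc1nccc(N2CC[C@H](NC(=O)Nc3ccc(CN4CCCC4)c(C(F)(F)F)c3)C2)n1` gives 37400 nM
- compound 3 `CCN1CCN(Cc2ccc(NC(=O)N[C@H]3CCN(c4ccnc(NC)n4)C3)cc2C(F)(F)F)CC1` gives 132000 nM

Two steps fix where compound 3 stands, one being a 1.6-fold higher number from compound 1 to compound 3 (0.19 log units; within the scatter) and the other 3.5-fold higher number from compound 2 to compound 3 (0.55 log units; beyond the scatter) as well. It therefore shares the top of the range with one measured compound and lies clear of the other.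

Compound 4 `CNc1nccc(N2CC[C@H](NC(=O)Nc3ccc(CN4CCN(C)CC4)c(C(F)(F)F)c3)C2)n1` turns the 4-ethylpiperazin-1-yl group into 4-methylpiperazin-1-yl (hydrogen in place of methyl on a saturated chain carbon bound to an amine nitrogen in a ring), with hydrogen in place of methyl on a saturated chain carbon bound to an amine nitrogen in a ring.

Among the measured compounds shown here, no measured step makes this exact change. The nearest evidence comes from swapping the whole amine group, as in the other two steps and in a 2.3-fold lower number from compound 1 to compound 2 (0.36 log units; beyond the scatter) too. Those swaps alter far more of the structure, yet none went beyond a modest size. Removing one methyl is a much smaller edit, so no step beyond the scatter is expected in this assay (a 1.1-fold lower number from compound 3 to compound 4 (0.02 log units; within the scatter)). Compound 4 is expected at about 125000 nM (estimated range 65000 nM to 240000 nM).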

Compound 4, solubility: 67500 nM
Beside the measured number, compound 4's estimate is 1.9-fold (0.27 log units) above it; measured number inside the range.
By their numbers in this assay, from the lowest: compounds 2, 4, 1 and 3 (each within the scatter of the next, the first and the last beyond it).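

Among the compounds shown here, removing one methyl, which turns the 4-ethylpiperazin-1-yl group into 4-methylpiperazin-1-yl, is the smallest edit at this position so far, and in this assay it stays within the scatter (a 2.0-fold lower number from compound 3 to compound 4 (0.29 log units; within the scatter)). Compound 4 also lies within the scatter of both compounds with other amine groups (a 1.8-fold higher number from compound 2 to compound 4 (0.26 log units; within the scatter) and a 1.3-fold lower number from compound 1 to compound 4 (0.10 log units; within the scatter)), even though compound 2 lies beyond the scatter of both compound 1 and compound 3, so its number does not separate from any of the three. No measurement here offers an explanation for these numbers.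

The compounds shown leave open how this assay would read for a 4-propylpiperazin-1-yl group, with a longer chain in place of the ethyl. From the compounds shown here alone, a piperazin-1-yl group carrying hydrogen in place of the whole chain, or a morpholin-4-yl group, also remains open.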